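From Dichlorophenyl to Trifluoromethylphenyl Urea: Expected Activity

The compounds below may be only part of what the source reports. "The series", "measured", "known", "first", "only" and "open" are said of these compounds alone.

Compound 1 `COc1cc(Cl)cc(-c2nn(-c3cccc(NC(=O)Nc4ccc(Cl)c(C(F)(F)F)c4)c3)cc2-c2ccncc2)c1`: -58%
Compound 2 `COc1cc(Cl)cc(-c2nn(-c3cccc(NC(=O)Nc4cc(C(F)(F)F)cc(C(F)(F)F)c4)c3)cc2-c2ccncc2)c1`: -88%
Compound 3 `COc1cc(Cl)cc(-c2nn(-c3cccc(NC(=O)Nc4ccc(Cl)c(Cl)c4)c3)cc2-c2ccncc2)c1`: 11%

Three ureas sharing one core were measured in a functional assay on SF-268 cells (Homo sapiens) for inhibition, read by sulforhodamine B assay, with a stated time of 48 h, tested at 100 uM; on this read-out lower numbers stand for a stronger effect and higher numbers for a weaker effect at the one concentration tested. Compound 3 stands highest of the three numbers; its nearest neighbour is compound 1, and compound 2 lies furthest below it. Among the compounds with values here, the step of a number 69 percentage points higher from compound 1 to compound 3 (beyond the scatter) is the only single-point change measured, and it is large and beyond the scatter.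

Compound 4 `COc1cc(Cl)cc(-c2nn(-c3cccc(NC(=O)Nc4cccc(C(F)(F)F)c4)c3)cc2-c2ccncc2)c1` has not yet been measured. It differs from compound 3 by 3-(trifluoromethyl)phenyl in place of 3,4-dichlorophenyl on an amide-type nitrogen. This change removes both chlorines of compound 3 and introduces a trifluoromethyl group, as present in compound 1 and, twice, in compound 2. The measured step of a number 69 percentage points higher from compound 1 to compound 3 (beyond the scatter) runs in the opposite direction, chloro replacing trifluoromethyl, and produced a large rise; its reverse therefore bears on this step, though compound 4 also lacks a second substituent on that ring, for which no comparison exists.

Compound 4 is therefore expected to show a step of a number 46 percentage points lower from compound 3 to compound 4 (beyond the scatter) downward, beyond the scatter. The estimated value for compound 4 is -35%, within a range of -85% to 10%.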

Compound 4, a percentage reported as activity, at one concentration (the size of the read-out at that concentration, not a potency): -28%
Estimate against measurement, compound 4: 7 percentage points below; measured number inside the range.
By their numbers in this assay, from the lowest: compound 2; then compound 1; then compound 4; then compound 3.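

In this assay, exchanging 3,4-dichlorophenyl for 3-(trifluoromethyl)phenyl on the amide-type nitrogen gives a number 39 percentage points lower from compound 3 to compound 4 (beyond the scatter), so one trifluoromethyl group on this ring is enough for a stronger effect than the two chlorines give. The second substituent also counts: hydrogen in place of trifluoromethyl gives a number 60 percentage points higher from compound 2 to compound 4 (beyond the scatter), a large step, and hydrogen in place of chloro gives a number 30 percentage points higher from compound 1 to compound 4 (beyond the scatter), a modest one. Compound 3 goes against any reading that a second substituent strengthens the effect by itself, since it carries two chlorines yet stands above compound 4, which shows that the trifluoromethyl group matters here.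

From the compounds shown here alone, how a nitrile, an amine or a carboxylic acid would fare in place of the trifluoromethyl group remains open. Nothing shown accounts for these differences in cause.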